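This account rests on a few compounds, and the source may have more. Where it says the series, first, only, none or still open, it means among the compounds named here.

Measured in a functional assay on MCF7 cells (Homo sapiens) for cytotoxicity, read by MTT assay, with a stated time of 72 h; a higher number here means a weaker inhibitor, a lower number a stronger inhibitor:
- compound 1 `NC(=O)N1CCN(C(=S)SCc2cn(Cc3ccc(F)cc3)nn2)CC1` gives 22100 nM
- compound 2 `CCN(C)C(=O)N1CCN(C(=S)SCc2cn(Cc3ccc(F)cc3)nn2)CC1` gives 2150 nM

For the measured compounds named here, compound 2 stands at the lower of the two numbers; the only measured step, a 10-fold lower number from compound 1 to compound 2 (1.01 log units; beyond the scatter), separates it from compound 1. Compound 3 `O=C(NC1CCCCC1)N1CCN(C(=S)SCc2cn(Cc3ccc(F)cc3)nn2)CC1` differs from compound 2 by cyclohexylamino in place of ethyl(methyl)amino on a carbonyl carbon. Going by the values given here, that single step is the only guide, and it concerns a different exchange of groups on the same carbonyl carbon, so it bears on this step only loosely. The expectation for compound 3 is a small step, a 1.4-fold lower number from compound 2 to compound 3 (0.16 log units; within the scatter), which may stay within the scatter. Compound 3 is therefore estimated at 1500 nM, with a range from 400 nM to 6000 nM.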

Compound 3, half-maximal inhibitory concentration: > 128000 nM
Compound 3 ended at the assay's limit (the forecaster's own chance of this, stated with the estimate: 5%); middle value at least 85-fold (1.93 log units) away from the limit.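

Compound 3 carries only a limit and not a number: the limit of > 128000 nM in this assay, at which 1 of the 3 values shown sits.

Even so, the step is clear: an at least 59-fold higher number from compound 2 to compound 3 (1.77 log units; beyond the scatter). The other comparison gives an at least 5.7-fold higher number from compound 1 to compound 3 (0.76 log units; beyond the scatter), so cyclohexylamino falls behind both amino and ethyl(methyl)amino, and a larger group on this carbonyl carbon does not by itself bring a lower number.

The compounds shown leave open whether the ring or the hydrogen on the nitrogen goes with this loss. Butylamino, an open chain that keeps that hydrogen, and piperidin-1-yl, a ring without it, would help separate the two.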